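The source may report more compounds than this note shows. Statements on the series, on what has been measured and on what is new or still open speak of the compounds shown alone.

Compound 1 `CCCCCc1ccc(CCc2cc3cn([C@H]4C[C@H](O)[C@@H](CO)O4)c(=O)nc3o2)cc1`, compound 2 `CCCc1ccc(C#Cc2cc3cn([C@H]4C[C@H](O)[C@@H](CO)O4)c(=O)nc3o2)cc1` and compound 3 `CCCCCc1ccc(-c2cc3cn([C@H]4C[C@H](O)[C@@H](CO)O4)c(=O)nc3o2)nc1` share one core and differ in the side chain attached to it. All three were tested in an ADME assay on HEL cells (Homo sapiens) for cytotoxicity, with a stated time of 3 days (a higher number here means that more compound is tolerated, a lower number that less compound is tolerated), and none of them gave an exact figure. Compound 1 gives > 470000 nM here, which is a limit and not a number. Compound 2 gives > 120000 nM here, which is also a limit. Compound 3 gives > 50000 nM here, again a limit. Compound 2 therefore has no exact position, and the three compounds cannot be ranked against one another.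

Compound 4 `O=c1nc2oc(C#Cc3ccccc3)cc2cn1[C@H]1C[C@H](O)[C@@H](CO)O1` differs from compound 2 in a single place: hydrogen in place of propyl on an aromatic carbon This is hydrogen in place of propyl on an aromatic carbon, so 4-propylphenyl becomes phenyl. Within the data shown here, no measured pair shows what this change does in this assay so the expectation is cautious. The estimated step that the limit leaves unreadable from compound 2 to compound 4 stays within the usual scatter, with neither direction favoured, and another limit is the likeliest report. Compound 4 is estimated at 150000 nM with 50000 nM to 450000 nM as its expected range.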

Compound 4, half-maximal cytotoxic concentration: > 570000 nM
Compound 4: no number, only a limit (the forecaster's own chance of this, stated with the estimate: 85%); middle value at least 3.8-fold (0.57 log units) away from the limit.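

Compound 2 and compound 4 each give only a limit in this assay, so no size or direction can be read for the change between them. The compounds shown leave open whether replacing 4-propylphenyl with phenyl alters how much compound is tolerated.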